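The source may report more compounds than this note shows. Statements on the series, on what has been measured and on what is new or still open speak of the compounds shown alone.

Compound 1 `C#CCOc1ccc(/C=C/C(=O)c2cccn2C)cc1OC` is the reference point of this account. In a functional assay on CCRF-CEM cells (Homo sapiens) for cytotoxicity, with a stated time of 72 h (a lower number here means a stronger inhibitor, a higher number a weaker inhibitor), compound 1 gives > 50000 nM, which is only a limit of the assay and not a number. That reading sits at the limit of > 50000 nM in this assay, at which 1 of the 3 values shown sits, so compound 1 is placed no more precisely than that. The two other measured compounds offer a sense of scale: compound 2 `C#CCOc1ccc(/C=C/C(=O)c2ccc(-n3ccnc3)cc2)cc1OC` gives 15000 nM in this assay, and compound 3 `C=CCc1cc(C(C)=O)ccc1OCC=C(C)C` gives 16300 nM in this assay, and these two values lie within the scatter of each other.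

Compound 4 `C#CCOc1ccc(/C=C/C(=O)c2ccccc2C)cc1OC` has not yet been measured. It differs from compound 1 in one place: 2-methylphenyl in place of 1-methyl-1H-pyrrol-2-yl on a carbonyl carbon. Within the data shown here, no measured step connects these two structures, so the direction must be judged from the change alone. The expected step is estimated as an at least 1.6-fold lower number from compound 1 to compound 4 (0.22 log units; that floor lies within the scatter), and this expectation carries wide uncertainty. Compound 4 is therefore expected to give about 30000 nM in this assay, somewhere between 10000 nM and 80000 nM, with a real chance that only a limit is reported again.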

Compound 4, half-maximal inhibitory concentration: 6950 nM
The estimate for compound 4 lay 4.3-fold (0.64 log units) above the measured number, outside the stated range (below it).
By their numbers in this assay, from the lowest: compound 4; then compounds 2 and 3 (each within the scatter of the next). At a limit, above all of these: compound 1.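

Among these compounds, on the carbonyl carbon, the group carried there proves to matter in this assay: 2-methylphenyl in place of 1-methyl-1H-pyrrol-2-yl gives an at least 7.1-fold lower number from compound 1 to compound 4 (0.85 log units; beyond the scatter), the first step in this account that joins two measured structures. The earlier compounds shown here offered only a sense of scale, whereas this single change takes the shared core from a limit to a measured number. The value for compound 1 is a limit of the assay, so the step reads only as a floor and its true size stays unknown: the limit of > 50000 nM in this assay, at which 1 of the 4 values shown sits.

As far as these compounds go, it remains open whether the step comes from the change of ring or from the methyl on it, which a plain phenyl on the same carbonyl carbon would help to separate. Also open is how a phenyl bearing an amine or a carboxylic acid would read here, and no measured property shown explains the step.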